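Removing the trifluoromethyl from the cyclopropyl of compound 3

The compounds below may be only part of what the source reports. "The series", "measured", "known", "first", "only" and "open" are said of these compounds alone.

Compound 3 `O=C(Cn1nnc(-c2ccccc2)n1)Nc1cc(C2(C(F)(F)F)CC2)nn1C1CCCCC1` sits at the bottom of this small set: in an assay on HEK293 cells for activation of Kir3.1/Kir3.2 (Homo sapiens), read by thallium flux (a lower number here means a smaller maximal response, a higher number a larger maximal response), compound 3 is recorded as "not active" (no number reported), with no number given. Compound 1 `CC1CC1c1cc(NC(=O)Cn2nnc(-c3ccccc3)n2)n(C2CCCCC2)n1`, which carries 2-methylcyclopropyl on the same aromatic carbon, gives 78%. Compound 2 `CC1(c2cc(NC(=O)Cn3nnc(-c4ccccc4)n3)n(C3CCCCC3)n2)CC1` is reported only as a limit of the assay, > 10%. The step that the limit leaves unreadable from compound 1 to compound 2 therefore cannot be read, a consequence of the limit of > 10% in this assay, at which 1 of the 3 values shown sits. The new compound 4 `O=C(Cn1nnc(-c2ccccc2)n1)Nc1cc(C2CC2)nn1C1CCCCC1` differs from compound 3 by hydrogen in place of trifluoromethyl on a saturated ring carbon; cut one bond further out, the change reads 1-(trifluoromethyl)cyclopropyl to cyclopropyl. Among the compounds with values here, no measured step covers this exact change: the only readable value belongs to compound 1, and the step from compound 1 to compound 2 is hidden behind a limit, so no size or direction can be borrowed from it. An estimate for compound 4 must rest on compound 3 standing at no activity and compound 1 at 78%. Compound 4 is expected to reach roughly 50%, between 15% and 85%.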

Compound 4, largest response reached (Emax), in percent of the reference or control that the assay uses: 45%
For compound 4 the middle estimate is 5 percentage points above the measured one; the range from low to high includes it.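

In this assay compound 4, with a plain cyclopropyl, gives 45%, whereas compound 3, with 1-(trifluoromethyl)cyclopropyl, is recorded as "not active" (no number reported), so a response at this position does not depend on a substituent on the three-membered ring. Hydrogen in place of methyl on that ring gives a number 33 percentage points lower from compound 1 to compound 4 (beyond the scatter), so 2-methylcyclopropyl holds a larger maximal response here than cyclopropyl does. The value of compound 2 is only a limit, > 10%, and the steps that involve it cannot be read: the limit of > 10% in this assay, at which 1 of the 4 values shown sits.

As far as these compounds go, it remains open whether a single methyl on the ring carbon that carries trifluoromethyl in compound 3 keeps the response. From the compounds shown here alone, how an ethyl, a hydroxymethyl or an amine on the cyclopropyl would behave in this assay also remains open.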